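The source may hold more compounds than are shown below. What is called first, only, known or untested is meant among the compounds shown, and "the series" means these compounds.

Measured so far in an ADME assay on MT4 cells (Homo sapiens) for cytotoxicity, read by MTT assay; a lower number here means that less compound is tolerated, a higher number that more compound is tolerated:
compound 1 `CCc1c(Cc2c(Cl)cccc2Cl)nc(SCC(=O)c2ccccc2)[nH]c1=O`: > 52000 nM, a limit
compound 2 `O=C(CSc1nc(Cc2c(F)cccc2Cl)cc(=O)[nH]1)c1ccccc1`: > 13000 nM, a limit
compound 3 `Cc1c(Cc2c(F)cccc2Cl)nc(SCC(=O)c2ccccc2)[nH]c1=O`: > 12000 nM, a limit

Compound 3 has no number, only a limit: it stands at the limit of > 12000 nM in this assay, at which 1 of the 3 values shown sits. The other two compounds are also limits, so the series has no readable half-maximal cytotoxic concentration yet.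

The next structure is compound 4 `CCc1c(Cc2c(F)cccc2Cl)nc(SCC(=O)c2ccccc2)[nH]c1=O`. The change is methyl in place of hydrogen on a saturated chain carbon bound to an aromatic carbon, which is methyl in place of hydrogen on a saturated chain carbon bound to an aromatic carbon, or, cut one bond further out, methyl to ethyl.

Going by the values given here, only one measured step bears on it: a step that the two limits leave unreadable from compound 2 to compound 3. That step is methyl in place of hydrogen on an aromatic carbon, so it is a different place, and it gives no size to carry over. Compound 1 also carries an ethyl group, and its value is a limit as well: > 52000 nM.

No step beyond the scatter is expected in this assay, in either direction, and another limit is the likeliest result. The expectation rests on compound 3, whose limit is > 12000 nM. The estimated change is a step that the limit leaves unreadable from compound 3 to compound 4. For compound 4 the expected value is 20000 nM, with an estimated range of 9000 nM to 60000 nM.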

Compound 4, half-maximal cytotoxic concentration: > 12000 nM
Compound 4: a limit, no number (the forecaster's own chance of this, stated with the estimate: 80%); the middle value does not contradict the limit.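

In this assay compound 4 gives only a limit, as do compound 1, compound 2 and compound 3, so the steps from compound 1, compound 2 and compound 3 to compound 4 cannot be read. The compounds shown leave open where the half-maximal cytotoxic concentration of any of them lies, and whether any of these changes shifts it.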